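Shortening the alkyl chain of a phosphate dithiocarbamate

The compounds below may be only part of what the source reports. "The series", "measured", "known", "first", "only" and "open" are said of these compounds alone.

Of the compounds shown here, three have been measured in a functional assay on MCF7 cells (Homo sapiens) for inhibition, read by MTT assay, with stated times of 18 h and 4 h; on this read-out lower numbers stand for stronger inhibition and higher numbers for weaker inhibition. Compound 1 `CCCCCCCCCCCCCCCCOP(=O)(O)OCCSC(=S)N1CCCCC1` gives 29000 nM, compound 2 `CCCCCCCCCCOP(=O)(O)OCCSC(=S)N1CCCC1` gives 70000 nM, and compound 3 `CCCCCCCCCCOP(=O)(O)OCCSC(=S)N1CCN(C)CC1` gives 99600 nM. Going by the values given here, compound 2 stands second highest of the three; the one measured step, a 1.4-fold higher number from compound 2 to compound 3 (0.15 log units; within the scatter), lies within the scatter. Compound 4 `CCCCCCCCOP(=O)(O)OCCSC(=S)N1CCCC1` differs from compound 2 only in the chain: hydrogen in place of ethyl on a saturated chain carbon, eight bonds along the chain from an oxygen on an unsaturated carbon. Among the compounds with values here, no measured step changes the chain alone; the longer-chain compound 1 gives the lowest number, but it also differs in the ring, so the two values show only a loose hint. Compound 4 is therefore expected to give 100000 nM, between 45000 nM and 250000 nM, a step of a 1.4-fold higher number from compound 2 to compound 4 (0.15 log units; within the scatter) of modest size, not confidently beyond the scatter.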

Compound 4, half-maximal inhibitory concentration: 53000 nM
For compound 4 the middle estimate is 1.9-fold (0.28 log units) above the measured one; the range from low to high includes it.
By their numbers in this assay, from the lowest: compounds 1, 4, 2 and 3 (each within the scatter of the next, the first and the last beyond it).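

In this assay, hydrogen in place of ethyl at this place on the chain, eight bonds along the chain from an oxygen on an unsaturated carbon, gives a 1.3-fold lower number from compound 2 to compound 4 (0.12 log units; within the scatter). Going by these compounds alone, this is the first reading of the chain alone with the rest of the molecule held fixed, and this shortening leaves the two compounds indistinguishable on this read-out.

Still open, on these data alone, is whether a longer chain on the core of compound 2, or a carboxylic acid at the chain end, would move the number beyond the scatter. No available measurement offers an explanation for this result.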